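The source may report more compounds than this note shows. Statements on the series, on what has been measured and on what is new or still open speak of the compounds shown alone.

In an assay on isolated protein for inhibition of Calpain-1 catalytic subunit (Homo sapiens), read by fluorescence, with a stated time of 60 min, tested at 1 uM (on this read-out higher numbers stand for more inhibition at the one concentration tested (going by the name of the read-out) and lower numbers for less inhibition), the three measured compounds give the following:

Compound 1 `COCCN/C(=C1/N=CN(CCOC)C1=O)c1cc2ccccc2[nH]1`: 73.7%
Compound 2 `CC(C)N/C(=C1/N=CN(C(C)C)C1=O)c1cc2ccccc2[nH]1`: 57.8%
Compound 3 `CCCCN/C(=C1/N=CN(CCCC)C1=O)c1cc2ccccc2[nH]1`: 14%

Compound 1 stands highest of the three numbers in this assay. Its nearest neighbour is compound 2, whose number is lower by a gap beyond the usual scatter, and the furthest is compound 3, whose number is lower by a gap well beyond it. No two of these compounds differ in only one place, so no single structural step between measured compounds is available.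

Compound 4 `COCCN/C(=C1/N=C(c2ccccc2)N(CCOC)C1=O)c1cc2ccccc2[nH]1` is not yet measured. It differs from compound 1 in one place: phenyl in place of hydrogen on a carbon with a double bond to nitrogen. Going by the values given here, nothing among the measured compounds shows what a phenyl on a carbon with a double bond to nitrogen of the five-membered non-aromatic ring does in this assay; the change is therefore judged without a precedent. A modest step downward is expected, a number 18.7 percentage points lower from compound 1 to compound 4 (beyond the scatter), since the new group is large compared with the hydrogen it replaces and the three measured compounds already span a wide range. Compound 4 is thus estimated at 55%, within a range from 20% to 85%.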

Compound 4, a percentage reported as inhibition, at one concentration (the size of the read-out at that concentration, not a potency): 21.5%
Compound 4: middle estimate off by 33.5 percentage points, on the high side, and the stated range covers the measured number.
By their numbers in this assay, from the lowest: compounds 3 and 4 (each within the scatter of the next); then compound 2; then compound 1.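

In this assay, phenyl in place of hydrogen on a carbon with a double bond to nitrogen gives a number 52.2 percentage points lower from compound 1 to compound 4 (beyond the scatter), a large step. Going by these compounds alone, this is the first reading of this position, and it shows that the position is not indifferent to what it carries: a single change here, with both 2-methoxyethyl groups and the rest of the core of compound 1 kept, is enough to move the number well beyond the scatter. No measurement at hand explains why this change has so large an effect.

The compounds shown leave open whether a methyl or an amine on this carbon would stay close to hydrogen or fall as far as phenyl. They also leave open whether phenyl here would have a similar effect with isopropyl or butyl chains in place of the 2-methoxyethyl groups.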